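Replacing a Side Group on a Slow-Clearance Compound

A few compounds are considered here, and "the series" means these few. Any claim that something is new, unique, unknown or untested is made for them only; others in the source may bear on it.

Compound 1 `CC(C)(c1ccccc1)c1nc2c(C(F)(F)F)cccc2c(C(=O)O)c1O` in an in vivo ADME assay on the whole organism (strain Sprague-Dawley) for pharmacokinetics, with Rattus norvegicus as the target; on this read-out higher numbers stand for fast clearance and lower numbers for slow clearance: 3.7 mL/min/kg
Compound 2 `O=C(O)c1c(O)c(C2(c3ccccc3)CC2)nc2c(C(O)(C(F)(F)F)C(F)(F)F)cccc12` in this assay: 1 mL/min/kg

For the measured compounds named here, of these two numbers, the one for compound 1 is the higher, and the gap to compound 2 lies beyond the usual scatter. Compound 1 and compound 2 differ in more than one place, so their gap does not show what a single change would do.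

Compound 3 `O=C(O)c1c(O)c(C2Cc3ccccc3C2)nc2c(C(F)(F)F)cccc12` keeps the core of compound 1 and alters one group, on an aromatic carbon next to the ring nitrogen: 2,3-dihydro-1H-inden-2-yl in place of 1-methyl-1-phenylethyl on an aromatic carbon. Going by the values given here, no measured pair tests this change, so the expectation rests on compound 1 at 3.7 mL/min/kg as the closest measured structure. The expected size is a 1.2-fold higher number from compound 1 to compound 3 (0.09 log units; within the scatter), a slight rise that stays within the scatter. For compound 3 the estimated clearance in this assay is 4.5 mL/min/kg, with an expected range of 1.5 mL/min/kg to 13 mL/min/kg.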

Compound 3, clearance: 28 mL/min/kg
Estimate against measurement, compound 3: 6.2-fold (0.79 log units) below, outside the stated range (above it).
By their numbers in this assay, from the lowest: compound 2; then compound 1; then compound 3.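

Size alone does not settle what happens at this position, on an aromatic carbon next to the ring nitrogen. In this assay, 2,3-dihydro-1H-inden-2-yl in place of 1-methyl-1-phenylethyl gives a 7.6-fold higher number from compound 1 to compound 3 (0.88 log units; beyond the scatter), a step beyond the usual scatter toward faster clearance. The two groups have the same heavy atom count, each has one six-membered aromatic ring of carbon only, and neither has a hydrogen-bond donor or acceptor, yet the data give no explanation for the rise.

As far as these compounds go, it remains open whether a group without a ring, such as tert-butyl, or one carrying an amine, would keep clearance near that of compound 1 or raise it further. Also unsettled is whether this change would have a similar effect if the trifluoromethyl group elsewhere on the core were replaced.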